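The compounds below may be only part of what the source reports. "The series", "measured", "known", "first", "only" and "open" are said of these compounds alone.

Compound 1 `COCc1ccccc1C1CCc2nc[nH]c2C1` and compound 2 `Clc1ccccc1C1CCc2nc[nH]c2C1` share the same core and differ only in the group on the six-membered aromatic ring of carbon only. In a functional assay on CHO cells for agonist activity at Alpha-1B adrenergic receptor (Homo sapiens), read by FLIPR and calcium flux (a lower number here means that less compound is needed, a higher number that more compound is needed for the effect), compound 1 gives > 10000 nM; > 10000 nM (2 entries), which is a limit of the assay rather than a number, and a second entry returned the same limit. Compound 2 in this assay gives > 10000 nM, again a limit and not a number. Compound 2 therefore stands nowhere on a scale of measured numbers; it sits at the limit of > 10000 nM in this assay, at which 1 of the 2 values shown sits. Compound 3 `COc1ccccc1C1CCc2nc[nH]c2C1` is not yet measured. Its change from compound 2 is methoxy in place of chloro on an aromatic carbon. Among the measured compounds shown here, no measured pair here shows what such a swap does. The step in this assay is expected to be a step that the limit leaves unreadable from compound 2 to compound 3, that is, no change beyond the usual scatter. Compound 3 is expected to give 15000 nM, between 3000 nM and 60000 nM, most likely once more only a limit.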

Compound 3, half-maximal effective concentration: > 10000 nM
Compound 3: a limit, no number; the forecaster's own chance of this, stated with the estimate: 85%; the middle value does not contradict the limit.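

In this assay compound 3 gives > 10000 nM, a limit and not a number. Compound 2 also rests on a limit, so no step between compound 2 and compound 3 can be read: the limit of > 10000 nM in this assay, at which 2 of the 3 values shown sit.

The compounds shown leave open whether methoxy in place of chloro changes anything, as none of them carries a number.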